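This account rests on a few compounds, and the source may have more. Where it says the series, first, only, none or still open, it means among the compounds named here.

Working notes on the phenoxy-substituted pyridine N-oxide series, read in a functional assay on the whole organism with Mus musculus as the target, in the maximal electroshock model, with a stated time of 30 min; a lower number here means that less compound is needed, a higher number that more compound is needed for the effect.

Three compounds have numbers. Compound 1 `Cc1cc(Oc2ccccc2)c[n+]([O-])c1` gives 100 mg/kg in this assay. Compound 2 `N#Cc1cc[n+]([O-])cc1Oc1ccccc1` gives 300 mg/kg. Compound 3 `COc1ccc(Oc2c[n+]([O-])ccc2C)cc1` gives 300 mg/kg. Compound 2 stands level with compound 3 at the digits shown, the two together the highest numbers of the three; its nearest neighbour is compound 3, with no change beyond the scatter, and its furthest is compound 1, which sits at a lower number by a margin beyond the scatter. Among the compounds with values here, no two measured compounds differ in a single place, so no step between them can be isolated.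

The next compound, compound 4 `CCc1cc[n+]([O-])cc1Oc1ccccc1`, is not yet measured. It differs from compound 2 in one place: ethyl in place of cyano on an aromatic carbon. Cyano leaves and ethyl enters at the same aromatic carbon.

Nothing measured in the series pairs a cyano with an alkyl group at one position, so the size of the step is uncertain. Compound 3 carries a methyl on the same core and gives 300 mg/kg, which argues for no move beyond the scatter. An estimate for compound 4 is 200 mg/kg, with a range of 70 mg/kg to 600 mg/kg, corresponding to an expected step of a 1.5-fold lower number from compound 2 to compound 4 (0.18 log units; within the scatter).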

Compound 4, minimum effective dose: 30 mg/kg
Estimate against measurement, compound 4: 6.7-fold (0.82 log units) above; the whole stated range lies above it.
By their numbers in this assay, from the lowest: compound 4; then compound 1; then compounds 2 and 3 (each within the scatter of the next).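

In this assay, within the data shown here, ethyl in place of cyano on this aromatic carbon gives a 10-fold lower number from compound 2 to compound 4 (1.00 log units; beyond the scatter) and is the first step that can be read. The position, opposite the ring nitrogen and ortho to a group of 7 heavy atoms, is therefore not indifferent to what it carries: cyano and ethyl each count 2 heavy atoms, so the step separates two groups of equal heavy-atom count, with the triple bond and the hydrogen-bond acceptor of cyano leaving. No measurement at hand bears on the reason for this step.

With only cyano and ethyl read at this position, the compounds shown leave open whether the number tracks the length of the alkyl chain, as a methyl, a propyl or a longer chain in the same place would show, or whether the departure of cyano alone carries the step. On these data alone, a hydrogen, an amine or a methoxy on this carbon would separate those two readings, and whether the step holds with a substituent on the phenoxy ring also remains open.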